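Aryl in place of amine chain on a piperazine nitrogen

The source may hold more compounds than are shown below. What is called first, only, known or untested is meant among the compounds shown, and "the series" means these compounds.

Measured compounds:
Compound 1, `Cc1cccc2sc(NC(=O)CCN3CCN(C(C)(C)C)CC3)nc12`: in an assay on HEK293 cells for antagonist activity at P2X purinoceptor 7 (Homo sapiens), read by fluorescence, with stated times of 30 min and 120 min (on this read-out higher numbers stand for weaker inhibition and lower numbers for stronger inhibition), compound 1 gives no result reported
Compound 2, `Cc1cccc2sc(NC(=O)CCN3CCN(CCCN(C)C)CC3)nc12`: 18100 nM
Compound 3, `CCCCCCN1CCN(CCC(=O)Nc2nc3c(C)cccc3s2)CC1`: in this assay compound 3 gives no result reported

Three compounds share the same core and differ only in the group on the ring nitrogen of the six-membered non-aromatic ring with two nitrogens. For compound 1 and compound 3 no number was obtained. Compound 2 therefore stands alone with a value: in this assay compound 2 gives 18100 nM, a weak inhibition, and there is no second number against which to place it. Within the data shown here, no step between two measured compounds exists, so nothing is known about how a change at this position shifts the read-out.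

Compound 4, `Cc1cccc2sc(NC(=O)CCN3CCN(c4ccccn4)CC3)nc12`, is the untested member. Its difference from compound 2 is pyridin-2-yl in place of 3-(dimethylamino)propyl on an amine nitrogen in a ring. Among the measured compounds shown here, with only one number available, the account expects no step beyond the usual scatter in this assay, in either direction; the estimated step is a 1.2-fold lower number from compound 2 to compound 4 (0.08 log units; within the scatter). For compound 4 the estimate in this assay is 15000 nM, with a range from 4000 nM to 60000 nM, and a real chance that only a limit rather than a number is reported.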

Compound 4, half-maximal inhibitory concentration: 1400 nM
Compound 4: the middle estimate sits 11-fold (1.03 log units) above what was measured, and the stated range ends above it.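

In this assay, pyridin-2-yl in place of 3-(dimethylamino)propyl on an amine nitrogen in a ring gives a 13-fold lower number from compound 2 to compound 4 (1.11 log units; beyond the scatter), the first sign that the read-out responds to the group at this position. The two groups match in their counts of heavy atoms, hydrogen-bond donors and hydrogen-bond acceptors, so those counts do not separate them; the visible difference is a six-membered aromatic ring where compound 2 has an open chain with no ring. Nothing measured here accounts for the size of this step.

The compounds shown leave open whether a phenyl group, which has no ring nitrogen, or pyridin-3-yl or pyridin-4-yl would give a similar read-out at this position. They also leave open whether a benzyl group, which places a methylene carbon before the aromatic ring, would keep the lower number of compound 4.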